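Dechlorination of the arylsulfonyl group in a pyrrolidinyl indole series

The source may report more compounds than this note shows. Statements on the series, on what has been measured and on what is new or still open speak of the compounds shown alone.

Measured compounds:
compound 1, `O=S(=O)(c1ccccc1)c1cn(C2CCN(Cc3ccccc3)C2)c2ccccc12`, "not determined" (no result reported)
compound 2, `O=S(=O)(c1cccc(Cl)c1)c1cn(C2CCNC2)c2ccccc12`, 48%

For the measured compounds named here, in a functional assay on HeLa cells for agonist activity at 5-hydroxytryptamine receptor 6 (Homo sapiens), read by cAMP accumulation and immunoassay, with a stated time of 10 min (on this read-out higher numbers stand for larger maximal responses and lower numbers for smaller maximal responses), compound 2 gives 48%, the only number at hand; compound 1 carries no result. Compound 3, `O=S(=O)(c1ccccc1)c1cn(C2CCNC2)c2ccccc12`, differs from compound 2 by hydrogen in place of chloro on an aromatic carbon. Going by the values given here, with no measured pair to calibrate a step, the expectation is a change no larger than the usual scatter, in either direction. Compound 3 is therefore expected to give about 45% in this assay, within 25% to 70%, which means an expected step of a number 3 percentage points lower from compound 2 to compound 3 (within the scatter).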

Compound 3, largest response reached (Emax), in percent of the reference or control that the assay uses: 70%
The estimate for compound 3 lay 25 percentage points below the measured number, within the range that was stated.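

In this assay, for the compounds shown here, the change from 3-chlorophenyl to phenyl gives a number 22 percentage points higher from compound 2 to compound 3 (beyond the scatter), the first calibrated step. At this aromatic carbon, chloro is therefore not required for agonist response, and hydrogen gives the larger maximal response in this single pair. No measurement at hand explains the step.

As far as these compounds go, whether fluoro, methyl or methoxy at the same place would keep the higher response remains open. Going by these compounds alone, compound 1 carries no number, so no step involving its benzyl group can be read.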